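The compounds below may be only part of what the source reports. "The series", "measured", "known", "first", "only" and "open" are said of these compounds alone.

Of the compounds shown here, two have been measured in an assay on cells for displacement of a labelled ligand from Glucagon receptor (Homo sapiens), in the presence of a further agent that is not named here; on this read-out lower numbers stand for stronger inhibition and higher numbers for weaker inhibition. Compound 1, `CCCC(Oc1ccc(-n2cc(C(F)(F)F)cn2)c(C)c1)c1ccc(C(=O)NCCC(=O)O)cc1`, gives 200 nM. Compound 2, `CCCC(Oc1ccc(-n2cc(F)cn2)cc1)c1ccc(C(=O)NCCC(=O)O)cc1`, gives 1700 nM and so stands as the higher of the two numbers, with the gap to compound 1 beyond the usual scatter. Compound 1 and compound 2 differ in more than one place, so that gap cannot be assigned to a single change.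

Compound 3, `CCCC(Oc1ccc(-n2cc(C)cn2)cc1)c1ccc(C(=O)NCCC(=O)O)cc1`, has not yet been measured. It differs from compound 2 in one place only: methyl in place of fluoro on an aromatic carbon. For the measured compounds named here, the one carbon-substituted analogue at this position of the pyrazole, compound 1, gives the lower number, but it also carries a further change on the aryl ring, so that reading is not clean.

A modest step toward lower numbers is expected, a 1.9-fold lower number from compound 2 to compound 3 (0.28 log units; within the scatter), rather than one of the size seen between compound 2 and compound 1. Compound 3 is estimated at 900 nM, with a range from 300 nM to 2500 nM.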

Compound 3, inhibition constant: 1900 nM
Compound 3: middle estimate off by 2.1-fold (0.32 log units), on the low side; low and high end bracket the measured number.
By their numbers in this assay, from the lowest: compound 1; then compounds 2 and 3 (each within the scatter of the next).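

For the compounds shown here, replacing 4-fluoro-1H-pyrazol-1-yl with 4-methyl-1H-pyrazol-1-yl is the only single-place change read so far at this position, and in this assay it gives a 1.1-fold higher number from compound 2 to compound 3 (0.05 log units; within the scatter), so the two groups are not told apart on this read-out. This single change therefore does not by itself reproduce the lower number of compound 1, which also carries trifluoromethyl here and a methyl on the aryl ring. Nothing measured beyond these numbers bears on this result.

The compounds shown do not separate the contribution of trifluoromethyl at this carbon from that of the aryl methyl, or show whether the two act together. As far as these compounds go, how a nitrile, an amine or a longer alkyl chain at this carbon would read also remains open.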